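The compounds below may be only part of what the source reports. "The series", "measured", "known", "first", "only" and "open" are said of these compounds alone.

Measured so far in a functional assay on MCF7 cells (Homo sapiens) for inhibition, read by MTT assay, with a stated time of 72 h; on this read-out lower numbers stand for stronger inhibition and higher numbers for weaker inhibition:
- compound 1 `Cc1ccc(NC(=O)c2ccc(/N=N\c3c[nH]c4ccccc34)cc2)cc1`: 42400 nM
- compound 2 `Cc1cccc(NC(=O)c2ccc(/N=N\c3c[nH]c4ccccc34)cc2)c1C`: 106000 nM
- compound 3 `O=C(Nc1ccccc1[N+](=O)[O-])c1ccc(/N=N\c2c[nH]c3ccccc23)cc1`: 101000 nM

Compound 3 stands second highest of the three numbers; compound 2 is within the scatter of it, compound 1 is clearly lower (a 2.4-fold higher number from compound 1 to compound 3 (0.38 log units; beyond the scatter)).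

Compound 4 `Cc1cccc(NC(=O)c2ccc(/N=N\c3c[nH]c4ccccc34)cc2)c1` is not yet measured; the change from compound 3 is 3-methylphenyl in place of 2-nitrophenyl on an amide-type nitrogen.

Within the data shown here, two steps bear on this. Replacing the methylphenyl of compound 1 by a nitrophenyl gave a 2.4-fold higher number from compound 1 to compound 3 (0.38 log units; beyond the scatter), and replacing it by a dimethylphenyl gave a 2.5-fold higher number from compound 1 to compound 2 (0.40 log units; beyond the scatter); compounds 2 and 3 sit within the scatter of each other (a 1.0-fold lower number from compound 2 to compound 3 (0.02 log units; within the scatter)). Returning to a single methylphenyl is therefore expected to move the number modestly downward, in this assay, but less surely than in compound 1. The estimate for compound 4 is 60000 nM (range 25000 nM to 150000 nM), an expected step of a 1.7-fold lower number from compound 3 to compound 4 (0.23 log units; within the scatter).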

Compound 4, half-maximal inhibitory concentration: 73400 nM
Compound 4: middle estimate off by 1.2-fold (0.09 log units), on the low side; low and high end bracket the measured number.
By their numbers in this assay, from the lowest: compounds 1, 4, 3 and 2 (each within the scatter of the next, the first and the last beyond it).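

The 3-methylphenyl on the amide-type nitrogen gives a number in this assay within the scatter of all three earlier compounds: the 4-methylphenyl (a 1.7-fold higher number from compound 1 to compound 4 (0.24 log units; within the scatter)), the 2-nitrophenyl (a 1.4-fold lower number from compound 3 to compound 4 (0.14 log units; within the scatter)) and the 2,3-dimethylphenyl, where hydrogen replaces methyl on an aromatic carbon (a 1.4-fold lower number from compound 2 to compound 4 (0.16 log units; within the scatter)). Compound 4 therefore does not divide the series into two separate groups, although compound 1 remains beyond the scatter of compound 2 and compound 3. No measured evidence accounts for these steps.

From the compounds shown here alone, whether an amine or a carboxylic acid on this phenyl would give a step beyond the scatter remains open. So does the outcome of a longer chain in place of the methyl.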